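The source may report more compounds than this note shows. Statements on the series, on what has been measured and on what is new or still open speak of the compounds shown alone.

Measured so far in a functional assay on A549 cells (Homo sapiens) for inhibition, read by CCK-8 assay, with a stated time of 72 h, tested at 1 uM; on this read-out lower numbers stand for less inhibition of growth and higher numbers for more inhibition of growth at the one concentration tested:
compound 1 `CN(C)C(=O)c1cc2cnc(Nc3ccc(NC(=O)C4(C(=O)Nc5ccc(Br)cc5)CC4)cc3)nc2n1C1CCCC1` gives -6.6%
compound 2 `CN(C)C(=O)c1cc2cnc(Nc3ccc(NC(=O)C4(C(=O)Nc5cccc(C(F)(F)F)c5)CC4)cc3)nc2n1C1CCCC1` gives 15.7%
compound 3 `CN(C)C(=O)c1cc2cnc(Nc3ccc(NC(=O)C4(C(=O)Nc5cccc(Cl)c5)CC4)cc3)nc2n1C1CCCC1` gives 8.3%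

Compound 3 stands second highest of the three numbers in this assay; its gap to compound 2 is within the scatter, while compound 1 lies beyond it, a number 14.9 percentage points higher from compound 1 to compound 3 (beyond the scatter). The step to compound 4 `Cc1ccc(NC(=O)C2(C(=O)Nc3ccc(Nc4ncc5cc(C(=O)N(C)C)n(C6CCCC6)c5n4)cc3)CC2)cc1` is 4-methylphenyl in place of 3-chlorophenyl on an amide-type nitrogen.

For the measured compounds named here, no measured step exchanges chloro for methyl or moves a substituent from one ring position to another, so the bearing of the known steps is indirect. Between the two 3-substituted phenyl amides the step is small, a number 7.4 percentage points lower from compound 2 to compound 3 (within the scatter), whereas the 4-bromophenyl amide of compound 1 sits lowest, a number 22.3 percentage points higher from compound 1 to compound 2 (beyond the scatter) and a number 14.9 percentage points higher from compound 1 to compound 3 (beyond the scatter). A 4-substituted phenyl entering in compound 4 is thus expected to give, if anything, a modest drop in this assay rather than a rise, though a change within the scatter is equally plausible. Compound 4 is estimated at 2% (range -13% to 17%), an expected step of a number 6.3 percentage points lower from compound 3 to compound 4 (within the scatter).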

Compound 4, percent growth inhibition at one concentration: 40.2%
Compound 4: the middle estimate sits 38.2 percentage points below what was measured, and the stated range ends below it.
By their numbers in this assay, from the lowest: compound 1; then compounds 3 and 2 (each within the scatter of the next); then compound 4.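

In this assay, for the compounds shown here, the aryl group on the amide-type nitrogen proves able to shift the number far more than the earlier compounds showed: the step is a number 31.9 percentage points higher from compound 3 to compound 4 (beyond the scatter) and, against the other 3-substituted phenyl amide, a number 24.5 percentage points higher from compound 2 to compound 4 (beyond the scatter), leaving compound 4 highest of the four. The largest step, with methyl in place of bromo on an aromatic carbon, is a number 46.8 percentage points higher from compound 1 to compound 4 (beyond the scatter), so compounds 1 and 4 both carry a 4-substituted phenyl yet stand at opposite ends, and a 4-substituted phenyl alone does not set the number. No available evidence accounts for these steps.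

Going by these compounds alone, whether the gain belongs to methyl itself or to methyl at this ring position remains open, as no pair here holds the substituent fixed while moving it. An ethyl group, a methoxy group or a carboxylic acid in place of that methyl would show how narrow the gain is.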